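A Tetrazole in Place of a Carboxy Group

This account rests on a few compounds, and the source may have more. Where it says the series, first, only, none or still open, it means among the compounds named here.

In a functional assay on the whole organism (stomach) with Rattus norvegicus as the target (on this read-out higher numbers stand for an effect only at larger amounts of compound and lower numbers for an effect already at smaller amounts), three compounds have been measured so far. Compound 3 (`O=C(O)c1ccc(NC(=O)c2ccc(C(=O)O)cc2)cc1`) gives 54.3 mg/kg on this read-out, compound 2 (`N#Cc1ccc(C(=O)Nc2ccc(-c3nn[nH]n3)cc2)cc1`) gives 54.4 mg/kg on the same read-out, and compound 1 (`CCCc1ccc(C(=O)Nc2cc(C(=O)O)cc(C(=O)O)c2)cc1`) gives 94.2 mg/kg there. All three numbers lie within the usual scatter of one another, so compound 3 stands level with both others and no ranking can be drawn from them.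

Compound 4 (`O=C(O)c1ccc(NC(=O)c2ccc(-c3nn[nH]n3)cc2)cc1`) is compound 3 with 2H-tetrazol-5-yl in place of carboxy on an aromatic carbon. Going by the values given here, no two measured compounds differ in one place only, so the effect of this exchange has not been seen directly. The nearest hint comes from compound 2, which also holds a 2H-tetrazol-5-yl on an aromatic carbon. Compound 2 at 54.4 mg/kg lies within the scatter of compound 3 at 54.3 mg/kg on this read-out.

A shift beyond the scatter is therefore not expected in this assay in either direction. The expected step is a 1.0-fold lower number from compound 3 to compound 4 (0.02 log units; within the scatter) and this estimate stays within the scatter. For compound 4 the estimated value is 52 mg/kg with an expected range from 25 mg/kg to 105 mg/kg once it is measured.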

Compound 4, dose for 50% inhibition: 3.5 mg/kg
The estimate for compound 4 lay 15-fold (1.17 log units) above the measured number, outside the stated range (below it).
By their numbers in this assay, from the lowest: compound 4; then compounds 3, 2 and 1 (each within the scatter of the next).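

In this assay, putting 2H-tetrazol-5-yl in place of carboxy on an aromatic carbon, para to a large group, gives a 16-fold lower number from compound 3 to compound 4 (1.19 log units; beyond the scatter), a large step beyond the scatter. Going by these compounds alone, this is the first exchange that can be read on its own: the earlier compounds differ from one another in more than one place and lay level, so they gave no sign that this position could respond so strongly to a single change. It shows that, on the core of compound 3, the choice between these two groups decides whether an effect appears only at larger amounts or already at much smaller ones, though nothing at hand gives a measured reason for the size of the step.

The compounds shown leave open whether another group at this place, such as a sulfonic acid or an amine, would give a similar step or none at all. They also leave open what happens to the number when the carboxy group that remains in compound 4 is exchanged for a second 2H-tetrazol-5-yl.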